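Swapping cyclohexyl for hexyl on a triple bond

A few compounds are considered here, and "the series" means these few. Any claim that something is new, unique, unknown or untested is made for them only; others in the source may bear on it.

Compound 1 `O=c1[nH]c(=O)n([C@@H]2O[C@H](CO)[C@@H](O)[C@H]2O)cc1C#CC1CCCCC1` gives 127000 nM
Compound 2 `CCC#Cc1c[nH]c(=O)[nH]c1=O` gives 253000 nM

In an ADME assay on A549 cells (Homo sapiens) for cytotoxicity, read by MTT assay (on this read-out higher numbers stand for lower toxicity in this test and lower numbers for higher toxicity in this test), these two values lie within the usual scatter of each other, so compound 1 stands level with compound 2. Compound 3 `CCCCCCC#Cc1cn([C@@H]2O[C@H](CO)[C@@H](O)[C@H]2O)c(=O)[nH]c1=O` keeps the core of compound 1 and makes one change, (hexyl in place of cyclohexyl on a triple-bonded carbon), which puts hexyl in place of cyclohexyl on a triple-bonded carbon. Within the data shown here, no measured pair shows this change, so compound 1 at 127000 nM is the closest guide. The expected result is a 1.1-fold lower number from compound 1 to compound 3 (0.02 log units; within the scatter), with nothing beyond the scatter and no clear direction. For compound 3 the estimate is 120000 nM, in an expected range from 50000 nM to 280000 nM.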

Compound 3, half-maximal cytotoxic concentration: 87200 nM
Compound 3: middle estimate off by 1.4-fold (0.14 log units), on the high side; the measured number falls inside the stated range.
By their numbers in this assay, from the lowest: compounds 3, 1 and 2 (each within the scatter of the next, the first and the last beyond it).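

Among these compounds, the first pair that differs in one place shows a 1.5-fold lower number from compound 1 to compound 3 (0.16 log units; within the scatter) in this assay. At this triple-bonded carbon, then, hexyl and cyclohexyl stand level: with the same number of carbons, the ring can be open or closed without a clear shift in this test. Nothing measured here offers a reason for this.

Still open, as far as these compounds go, is whether a longer chain such as decyl would move the number beyond the scatter. How a phenyl ring or an amine at the end of the chain would read at this position is also unknown.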